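The compounds below may be only part of what the source reports. "The series", "measured", "known", "first", "only" and "open" are said of these compounds alone.

Within the data shown here, in a functional assay on M21 cells (Homo sapiens) for antiproliferative activity, read by sulforhodamine B assay, with a stated time of 48 h (on this read-out lower numbers stand for stronger inhibition and higher numbers for weaker inhibition), compound 1 (`CN1CCN(c2ccc(S(=O)(=O)Oc3cccc(F)c3)cc2)C1=O`) gives 5800 nM, the only exact number available so far. Compound 2 (`COc1ccc(OS(=O)(=O)c2ccc(N3CCN(C)C3=O)cc2)cc1`) reaches only a limit of the assay, > 100000 nM. Among the measured compounds shown here, the single measured step, an at least 17-fold higher number from compound 1 to compound 2 (1.23 log units; beyond the scatter), is large and lies beyond the scatter, showing that the read-out can respond strongly to a change in the group on the oxygen.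

Compound 3 (`CCCCN1CCN(c2ccc(S(=O)(=O)Oc3cccc(F)c3)cc2)C1=O`) keeps that group of compound 1 and changes the molecule elsewhere: propyl in place of hydrogen on a saturated chain carbon bound to an amide-type nitrogen in a ring. The same difference can be read as methyl to butyl. The measured step therefore bears on this change only indirectly. For the measured compounds named here, it shows how far a single substitution can move the number, but it says nothing about chain length at this place, and no measured compound varies that chain. No direction can be drawn from the data, so no step beyond the scatter is expected, though the uncertainty is wide in both directions. The estimate starts from compound 1 at 5800 nM. The estimated step is a 1.2-fold higher number from compound 1 to compound 3 (0.08 log units; within the scatter). For compound 3, the expected value is 7000 nM, with an estimated range of 1500 nM to 35000 nM.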

Compound 3, half-maximal inhibitory concentration: > 100000 nM
Compound 3 was reported as a limit; the forecaster's own chance of this, stated with the estimate: 12%; middle value at least 14-fold (1.15 log units) from the limit.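

In this assay, the substituent on the amide-type ring nitrogen proves to matter: with the 3-fluorophenyl group on the oxygen left unchanged, going from methyl to butyl gives an at least 17-fold higher number from compound 1 to compound 3 (1.23 log units; beyond the scatter), so the read-out responds strongly at this place as well as at the group on the oxygen. Compound 3 gives > 100000 nM, which is a limit of the assay and not a number. The step therefore marks only the least the change can amount to, because the reading for compound 3 stops at the edge of what the assay reports: the limit of > 100000 nM in this assay, at which 2 of the 3 values shown sit.

With only methyl and butyl at this place, the compounds shown leave open how the number moves with chain length, and whether an ethyl or a propyl chain would stay near compound 1 or already lose the activity. They also leave open whether a butyl-length chain ending in an amine or a carboxylic acid would behave as the plain butyl chain of compound 3 does.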